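A Urea Aryl Swap Against an Inactive Background

The source may hold more compounds than are shown below. What is called first, only, known or untested is meant among the compounds shown, and "the series" means these compounds.

Of the compounds shown here, two have been tested so far in a functional assay on T47D cells (Homo sapiens) for inhibition, read by sulforhodamine B assay, with a stated time of 48 h; a lower number here means a stronger inhibitor of growth, a higher number a weaker inhibitor of growth. Compound 1 (`COc1cc(-c2nn(-c3cccc(NC(=O)Nc4cc(C(F)(F)F)cc(C(F)(F)F)c4)c3)cc2-c2ccncc2)ccc1Cl`) is one of them, and in this assay compound 1 reaches only the limit of > 50000 nM. Compound 2 (`COc1cc(-c2nn(-c3cccc(NC(=O)Nc4ccc(Cl)c(Cl)c4)c3)cc2-c2ccncc2)ccc1Cl`) likewise returns nothing more than the limit of > 50000 nM. Both results sit at the same limit, (the limit of > 50000 nM in this assay, at which 2 of the 2 values shown sit), so compound 2 stands nowhere distinct: no number places it either side of compound 1, and the pair shows only that neither reached a measurable total growth inhibition.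

Compound 3 (`COc1cc(-c2nn(-c3cccc(NC(=O)Nc4cccc(C(F)(F)F)c4)c3)cc2-c2ccncc2)ccc1Cl`) has not yet been measured. It differs from compound 2 in one place: 3-(trifluoromethyl)phenyl in place of 3,4-dichlorophenyl on an amide-type nitrogen. Going by the values given here, no measured step joins two compounds here, so no direction can be read from the numbers, and the expectation rests on the two limits alone. With both neighbours at the limit, the change is expected to leave compound 3 within the scatter of compound 2, most probably at the limit once more. Compound 3 is therefore expected to give 50000 nM in this assay, within a range of 15000 nM to 150000 nM. The step from compound 2 to compound 3 is estimated as a number no higher from compound 2 to compound 3 (the limit leaves the size open), which is no change beyond the scatter.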

Compound 3, concentration for total growth inhibition: > 50000 nM
Compound 3: only a limit was reported; the forecaster's own chance of this, stated with the estimate: 75%; the middle value lies on the limit itself.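

In this assay compound 3 gives > 50000 nM, which is a limit and not a number. Going by these compounds alone, no step to compound 3 from compound 1 or compound 2 can be read, as all three rest on one limit: the limit of > 50000 nM in this assay, at which 3 of the 3 values shown sit. The compounds shown leave open how far each lies from that limit, and whether any aryl group on this urea can give a measurable total growth inhibition.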